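The source may report more compounds than this note shows. Statements on the series, on what has been measured and on what is new or still open speak of the compounds shown alone.

Compound 1 `CCc1nc(-c2ccc(OC(F)(F)F)cc2OC)c(CC)nc1NC(CC)CC` is the starting point. In an in vitro ADME assay on microsomes (Rattus norvegicus) for metabolic stability (a higher number here means that the compound lasts longer, a lower number that the compound disappears faster), compound 1 gives 0.0417 h. Compound 2 `CCc1nc(-c2ccc(OC(F)(F)F)cc2OC)c(OC)nc1NC(CC)CC` differs from it in one place, (methoxy in place of ethyl on an aromatic carbon), and in this assay compound 2 gives 0.6 h; the step is a 14-fold higher number from compound 1 to compound 2 (1.16 log units; beyond the scatter). Compound 3 `CCc1nc(-c2ccc(OC)cc2C(F)(F)F)c(CC)nc1NC(CC)CC` has a different core, and how the two cores differ is not broken down here. In this assay compound 3 gives 0.0717 h, a number close to that of compound 1 and well under that of compound 2. Compound 4 `CCc1nc(NC(CC)CC)c(OC)nc1-c1ccc(OC)cc1C(F)(F)F` is not yet measured. It carries the same kind of change on the core of compound 3, (methoxy in place of ethyl on an aromatic carbon); it is not the same change, since here the new group is ortho to the (pentan-3-yl)amino group and meta to a large group, whereas in compound 2 it is ortho to a large group and meta to the (pentan-3-yl)amino group. Because a 14-fold higher number from compound 1 to compound 2 (1.16 log units; beyond the scatter) was large, a step in the same direction is expected from compound 3 to compound 4, an 8.4-fold higher number from compound 3 to compound 4 (0.92 log units; beyond the scatter), though taken somewhat smaller. Compound 4 is therefore estimated to give 0.6 h in this assay, expected between 0.15 h and 2 h.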

Compound 4, half-life: 2 h
Compound 4: the middle estimate sits 3.3-fold (0.52 log units) below what was measured, within the range that was stated.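

In this assay, methoxy in place of ethyl gives a 28-fold higher number from compound 3 to compound 4 (1.45 log units; beyond the scatter) on the second core, so this step is large and goes the same way as the earlier one on the core of compound 1. Two pairs of compounds are a small sample: they do not show that the change would behave alike on a third core, and they say nothing about why the number rises or about how the compounds would behave in any other test. What they do show is that the change carried over between these two cores in direction, and that the two steps cannot be told apart in size: the same change on two cores in this assay, a 14-fold higher number (1.16 log units; beyond the scatter) from compound 1 to compound 2 and a 28-fold higher number (1.45 log units; beyond the scatter) from compound 3 to compound 4, 1.9-fold (0.29 log units) apart, within the scatter of two such steps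

The compounds shown hold only ethyl or methoxy at this place on the core, so it stays open how an ethoxy group, a longer chain or an amine there would fare. The (pentan-3-yl)amino group is the same in all four compounds, which leaves open whether the step would keep its size with a smaller amine such as cyclopropylamine in that spot.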